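The source may hold more compounds than are shown below. What is called first, only, known or untested is meant among the compounds shown, and "the series" means these compounds.

In an ADME assay on the whole organism (plasma, Mus musculus, strain CD-1) for protein binding, read by LC-MS, with a stated time of 24 h (on this read-out lower numbers stand for a smaller free fraction and higher numbers for a larger free fraction), compound 1 `Cc1noc(-c2ccc(Oc3ccc(C(=O)O)cc3)cc2)c1NC(=O)O[C@H](C)c1ccccc1` gives 0.005 while compound 2 `CN(C(=O)OCc1c(-c2ccc(O[C@H]3CCC[C@H](C(=O)O)C3)cn2)nnn1C)C1CCCC1` gives 0.083 and compound 3 `Cc1noc(-c2ccc(O[C@H]3CCC[C@H](C(=O)O)C3)cn2)c1COC(=O)N(C)C1CCCC1` gives 0.015 as its free fraction. Compound 3 therefore stands in the middle of the three, with more of it free than compound 1 and less than compound 2, and both gaps lie beyond the scatter of repeated measurements.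

Compound 4 `CCCCN(C)C(=O)OCc1c(C)noc1-c1ccc(O[C@H]2CCC[C@H](C(=O)O)C2)cn1` has not been measured yet. It matches compound 3 except at one place, where the change is butyl in place of cyclopentyl on an amide-type nitrogen and amounts to butyl in place of cyclopentyl on an amide-type nitrogen. An open chain thus replaces a ring, and neither group carries a net charge. Among the compounds with values here, no pair of measured compounds shows what a swap of this kind does, so the expectation stays close to compound 3 at 0.015 and rests only on the modest size of the swap. The estimated step of a 1.2-fold higher number from compound 3 to compound 4 (0.08 log units; within the scatter) is a slight rise that is expected to stay within the scatter. For compound 4 the estimated value is 0.018 with an expected range from 0.009 to 0.036 on the same read-out.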

Compound 4, unbound fraction: 0.018
Compound 4: the middle estimate sits on the measured number at the digits printed; low and high end bracket the measured number.
By their numbers in this assay, from the lowest: compound 1; then compounds 3 and 4 (each within the scatter of the next); then compound 2.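

In this assay, butyl in place of cyclopentyl on an amide-type nitrogen gives a 1.2-fold higher number from compound 3 to compound 4 (0.08 log units; within the scatter), the only reading of a change at this place among the compounds shown. For this pair, then, replacing the all-carbon ring with an open carbon chain leaves the free fraction indistinguishable within the usual variation between repeated measurements. Nothing available explains why the two compounds read alike.

This single pair cannot show whether the result would hold for a longer chain such as hexyl, or for a chain carrying an amine or a hydroxyl group, which would bring in atoms other than carbon. It also leaves open whether the same swap would read alike on the core of compound 2.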